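Working notes: 3-methylphenyl to 4-fluorophenyl

A few compounds are considered here, and "the series" means these few. Any claim that something is new, unique, unknown or untested is made for them only; others in the source may bear on it.

Measured in a functional assay on OVCAR-3 cells (Homo sapiens) for antiproliferative activity, read by MTT assay, with a stated time of 24 h; on this read-out higher numbers stand for weaker inhibition and lower numbers for stronger inhibition:
- compound 1 `Cc1ccccc1-n1cc(-c2cccc(NS(=O)(=O)c3c[nH]c(=O)[nH]c3=O)c2)nn1` gives 6230 nM
- compound 2 `Cc1cccc(-n2cc(-c3cccc(NS(=O)(=O)c4c[nH]c(=O)[nH]c4=O)c3)nn2)c1` gives 4080 nM

Compound 2 (4080 nM) lies within the scatter of compound 1, so the two numbers do not separate and neither compound can be ranked. Compound 3 `O=c1[nH]cc(S(=O)(=O)Nc2cccc(-c3cn(-c4ccc(F)cc4)nn3)c2)c(=O)[nH]1` carries 4-fluorophenyl in place of 3-methylphenyl on an aromatic nitrogen. Going by the values given here, one measured step bears on this change, at the same place on the shared core: a 1.5-fold lower number from compound 1 to compound 2 (0.18 log units; within the scatter) stays within the scatter. Among the compounds with values here, no measured compound carries fluorine, so that step is only a loose guide. In this assay no step beyond the scatter is expected, in either direction. The expected step is a 1.1-fold higher number from compound 2 to compound 3 (0.04 log units; within the scatter) and remains an estimate. For compound 3 the estimated value is 4500 nM with an expected range of 1800 nM to 11000 nM as its bounds.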

Compound 3, half-maximal inhibitory concentration: > 20000 nM
Compound 3: only a limit was reported; the forecaster's own chance of this, stated with the estimate: 3%; middle value at least 4.4-fold (0.64 log units) from the limit.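

In this assay compound 3 is reported only as a limit, not as a number: the limit of > 20000 nM in this assay, at which 1 of the 3 values shown sits.

Even so, this position proves sensitive to the group it carries: 4-fluorophenyl in place of 3-methylphenyl gives an at least 4.9-fold higher number from compound 2 to compound 3 (0.69 log units; beyond the scatter), and 4-fluorophenyl in place of 2-methylphenyl gives an at least 3.2-fold higher number from compound 1 to compound 3 (0.50 log units; beyond the scatter). The earlier change between the two methylphenyl groups, a 1.5-fold lower number from compound 1 to compound 2 (0.18 log units; within the scatter), did not reveal this, so the aromatic nitrogen is not an indifferent site for this substituent in the series.

On these data alone, the true size of both new steps remains open, as does whether the change follows from the entering fluorine or from the leaving methyl group. How an unsubstituted phenyl or a phenyl bearing a carboxylic acid would read at this position also stays unresolved.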